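This account rests on a few compounds, and the source may have more. Where it says the series, first, only, none or still open, it means among the compounds named here.

Compound 1 `COC(=O)C1=C(C)N=C(C)/C(=C(\O)OC)C1c1cccc(OC)c1`: 191 nM
Compound 2 `COC(=O)C1=C(C)N=C(C)/C(=C(\O)OC)C1c1ccccc1C(F)(F)F`: 1.51 nM
Compound 3 `COC(=O)C1=C(C)N=C(C)/C(=C(\O)OC)C1c1ccccc1Br`: 7.59 nM

These values come from a functional assay (muscle tissue) with Cavia porcellus as the target; on this read-out lower numbers stand for an effect already at smaller amounts and higher numbers for an effect only at larger amounts of compound. Of the three numbers, compound 3 at 7.59 nM is the second highest, above compound 2 and below compound 1.

Compound 4 `COC(=O)C1=C(C)N=C(C)/C(=C(\O)OC)C1c1ccccc1C` carries methyl in place of bromo on an aromatic carbon. Within the data shown here, no measured compound carries this methyl, so the expectation rests on neighbouring changes. The closest is bromo in place of trifluoromethyl, a 5.0-fold higher number from compound 2 to compound 3 (0.70 log units; beyond the scatter), a modest step. The other, a 25-fold lower number from compound 1 to compound 3 (1.40 log units; beyond the scatter), is large, but it replaces 3-methoxyphenyl with 2-bromophenyl and so bears on this change only loosely. Compound 4 keeps a group at the place held by bromo in compound 3, so a small step towards a higher number is expected, perhaps not beyond the scatter. The expected step is a 1.8-fold higher number from compound 3 to compound 4 (0.27 log units; within the scatter). For compound 4 the estimated value is 14 nM, with an expected range from 5 nM to 45 nM.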

Compound 4, half-maximal effective concentration: 6.03 nM
Estimate against measurement, compound 4: 2.3-fold (0.37 log units) above, within the range that was stated.
By their numbers in this assay, from the lowest: compound 2; then compounds 4 and 3 (each within the scatter of the next); then compound 1.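

In this assay, methyl and bromo on this aromatic carbon, ortho to a large group, cannot be told apart (a 1.3-fold lower number from compound 3 to compound 4 (0.10 log units; within the scatter)), so the bromine atom itself is not needed to hold the number at this level. Trifluoromethyl remains separate from both groups: methyl in its place gives a step beyond the scatter (a 4.0-fold higher number from compound 2 to compound 4 (0.60 log units; beyond the scatter)), as bromo did. The large step from the 3-methoxyphenyl compound (a 32-fold lower number from compound 1 to compound 4 (1.50 log units; beyond the scatter)) also now appears with a second group, since 2-methylphenyl and 2-bromophenyl both lie far from compound 1.

No measurement at hand accounts for any of these steps. From the compounds shown here alone, what an amine, a nitrile or a carboxylic acid would give on this aromatic carbon stays open, as does the effect of a longer chain such as ethyl.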